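The source may report more compounds than this note shows. Statements on the series, on what has been measured and on what is new or still open speak of the compounds shown alone.

Measured compounds:
Compound 1, `O=C(CN(c1nc(Cl)nc2[nH]cnc12)C1CC1)NCC(=O)OCc1ccccc1`, in a functional assay on the whole organism (Tail, strain ICR) with Mus musculus as the target, in the tail flick test, with a stated time of 60 min, at a dose of 25 umol/kg by the oral route (a lower number here means a weaker effect, a higher number a stronger effect of the compound at the dose given), gives 41.9%.
Compound 2, `O=C(CN(c1nc(Cl)nc2[nH]cnc12)C1CC1)N[C@@H](CC(=O)OCc1ccccc1)C(=O)OCc1ccccc1`, gives 22.4%.
Compound 3, `O=C(O)CNC(=O)CN(c1nc(Cl)nc2[nH]cnc12)C1CC1`, gives 38.9%.

Compound 3 stands second among the three numbers; its nearest neighbour is compound 1, and the gap a number 3 percentage points lower from compound 1 to compound 3 (within the scatter) lies within the scatter, so the two cannot be ordered. Compound 2 lies furthest from compound 3, beyond the scatter.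

Compound 4, `C[C@H](NC(=O)CN(c1nc(Cl)nc2[nH]cnc12)C1CC1)C(=O)O`, has not yet been measured. It differs from compound 3 in one place: methyl in place of hydrogen on a saturated chain carbon bound to an amide-type nitrogen and a carbonyl carbon.

For the measured compounds named here, one measured step bears on this change. From compound 1 to compound 2 a group enters at the same place, on a saturated chain carbon bound to an amide-type nitrogen and a carbonyl carbon, and the result was a number 19.5 percentage points lower from compound 1 to compound 2 (beyond the scatter). The group that enters there is much larger than a methyl, so a smaller effect is expected here: a decrease that may not reach beyond the scatter, a number 4.9 percentage points lower from compound 3 to compound 4 (within the scatter). Compound 4 is therefore estimated at 34%, with a range from 18% to 50%.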

Compound 4, a percentage reported as activity, at one dose (the size of the read-out at that dose, not a potency): 44.6%
Compound 4: the middle estimate sits 10.6 percentage points below what was measured, within the range that was stated.
By their numbers in this assay, from the lowest: compound 2; then compounds 3, 1 and 4 (each within the scatter of the next).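

On a saturated chain carbon bound to an amide-type nitrogen and a carbonyl carbon, the change from carboxymethyl to 1-carboxyethyl leaves the tail flick response in this assay within the scatter (a number 5.7 percentage points higher from compound 3 to compound 4 (within the scatter)), so this position accepts a methyl without a measurable loss of effect at the dose given. For the compounds shown here, until now, the only group seen at this place was (benzyloxycarbonyl)methyl, which came with a loss beyond the scatter (a number 19.5 percentage points lower from compound 1 to compound 2 (beyond the scatter)), and the new step shows that such a loss does not follow from every group entering here. Nothing measured here explains why the two groups differ.

Going by these compounds, how a longer chain or an amine would behave at this place remains open. So does whether a methyl here would give a similar result with the benzyl ester in place of the carboxylic acid.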